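The source may report more compounds than this note shows. Statements on the series, on what has been measured and on what is new or still open speak of the compounds shown alone.

Measured in a physicochemical assay for solubility, read by HPLC, in phosphate buffer, measured as kinetic solubility, at pH 7.4; a lower number here means a less soluble compound, a higher number a more soluble compound:
compound 1 (`CCOC(=O)c1cc(-c2ccc(Cl)cc2)n(-c2ccc(S(N)(=O)=O)cc2)c1C`) at 4200 nM
compound 2 (`CCC(=O)c1cc(-c2ccc(F)cc2)n(-c2ccc(S(N)(=O)=O)cc2)c1C`) at 29300 nM
compound 3 (`CCC(=O)c1cc(-c2ccc(OC)cc2)n(-c2ccc(S(N)(=O)=O)cc2)c1C`) at 12800 nM

Compound 2 stands highest of the three and is the starting point for compound 4 (`CCOC(=O)c1cc(-c2ccc(F)cc2)n(-c2ccc(S(N)(=O)=O)cc2)c1C`). The change is ethoxy in place of ethyl on a carbonyl carbon in short, ethoxy in place of ethyl on a carbonyl carbon. Going by the values given here, the one measured step (a 2.3-fold lower number from compound 2 to compound 3 (0.36 log units; beyond the scatter)) is modest and lies elsewhere, so it bears only weakly. Compound 1 already carries the ethoxy there, but with chloro instead of fluoro, so its lower number than compound 2 cannot be credited to this change alone. In this assay a lower number is therefore expected, beyond the scatter but short of that whole gap. The estimated step is (a 3.3-fold lower number from compound 2 to compound 4 (0.51 log units; beyond the scatter)). The expected value for compound 4 is 9000 nM (estimated range 3500 nM to 22000 nM).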

Compound 4, solubility: 12600 nM
Compound 4: the middle estimate sits 1.4-fold (0.15 log units) below what was measured, within the range that was stated.
By their numbers in this assay, from the lowest: compound 1; then compounds 4 and 3 (each within the scatter of the next); then compound 2.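

In this assay, the carbonyl carbon now has a step of its own: with fluoro kept on the aromatic carbon, ethoxy in place of ethyl gives (a 2.3-fold lower number from compound 2 to compound 4 (0.37 log units; beyond the scatter)). With ethoxy kept, fluoro in place of chloro gives (a 3.0-fold higher number from compound 1 to compound 4 (0.48 log units; beyond the scatter)), so the gap between compound 2 and compound 1 splits into one step at each of the two places. No supporting data explain either step.

Still open, as far as these compounds go, is where an amide or a carboxylic acid on that carbonyl carbon would stand. Also open, from the compounds shown here alone, is whether the ethoxy step would hold with methoxy in place of fluoro.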